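A few compounds are considered here, and "the series" means these few. Any claim that something is new, unique, unknown or untested is made for them only; others in the source may bear on it.

Compound 1 `ClCc1cccc(Cn2cnc3c(Cl)nc(Cl)nc32)c1` is examined in a functional assay on K562 cells (Homo sapiens) for cytotoxicity, read by sulforhodamine B assay, with a stated time of 48 h; a higher number here means that more compound is tolerated, a lower number that less compound is tolerated. Compound 1 reaches only a limit there, > 100000 nM, so no exact number is known for it. Compound 2 `ClCc1ccccc1Cn1cnc2ncnc(Cl)c21` gives 83200 nM in this assay. Compound 3 `ClCc1cccc(Cn2cnc3c(Cl)ncnc32)c1` has not yet been measured. It differs from compound 1 by hydrogen in place of chloro on an aromatic carbon. For the measured compounds named here, since compound 1 sits at a limit (the limit of > 100000 nM in this assay, at which 1 of the 2 values shown sits), no measured step sets a size for this change, and no shift beyond the scatter is expected in this assay. Compound 3 is expected to stay weak, because compound 2 gives 83200 nM with a closely related core. Compound 3 is therefore estimated at 100000 nM, from 50000 nM to 250000 nM, and the expected step of a number no higher from compound 1 to compound 3 (the limit leaves the size open) is small.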

Compound 3, concentration lethal to 50% of the cells: 75900 nM
The estimate for compound 3 lay 1.3-fold (0.12 log units) above the measured number, within the range that was stated.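

In this assay compound 1 stands only at a limit, > 100000 nM. Hydrogen in place of chloro on this aromatic carbon, between two ring nitrogen atoms, gives an at least 1.3-fold lower number from compound 1 to compound 3 (0.11 log units; that floor lies within the scatter). The change thus replaces a limit with an exact number, but the true size of the step cannot be read: the limit of > 100000 nM in this assay, at which 1 of the 3 values shown sits.

The compounds shown leave open whether an amine or a methoxy group on this carbon would give a clearly lower number in this assay. Also open, as far as these compounds go, is what the chloro remaining in compound 3 contributes.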